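The compounds below may be only part of what the source reports. "The series", "measured", "known", "first", "only" and "open" are said of these compounds alone.

Notes on the series. Within the data shown here, compound 2 `Nc1cc(N)c2nc(-c3ccccc3)c(NCc3ccc(Cl)c(Cl)c3)nc2c1` is the one member with a number in a functional assay on SNB-19 cells (Homo sapiens) for inhibition, read by sulforhodamine B assay, with a stated time of 48 h; on this read-out higher numbers stand for weaker inhibition of growth and lower numbers for stronger inhibition of growth: compound 2 gives 22400 nM. Compound 1 `CCOC(=O)[C@H](CCC(=O)O)NC(=O)c1ccc(CNc2nc3cc(N)cc(N)c3nc2-c2ccccc2)cc1` returns only a limit in this assay, < 100000 nM. Among the measured compounds shown here, compound 1 therefore sits at the limit of < 100000 nM in this assay, at which 1 of the 2 values shown sits, and no step between measured compounds is available to size the effect of any change. Compound 3 `COc1ccc(CNc2nc3cc(N)cc(N)c3nc2-c2ccccc2)cc1` is not yet measured; it differs from compound 2 by 4-methoxyphenyl in place of 3,4-dichlorophenyl on a saturated chain carbon bound to a nitrogen on an aromatic ring. For the measured compounds named here, with no measured step to lean on, the step is expected to be small, either direction possible, and is estimated as a 1.3-fold higher number from compound 2 to compound 3 (0.13 log units; within the scatter). On that basis compound 3 is expected to give about 30000 nM in this assay, with a likely range from 8000 nM to 100000 nM. A reading at the limit is a real possibility for compound 3.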

Compound 3, concentration for 50% growth inhibition: 41700 nM
Compound 3: middle estimate off by 1.4-fold (0.14 log units), on the low side; low and high end bracket the measured number.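

Among these compounds, the first measured step at this position, on a saturated chain carbon bound to a nitrogen on an aromatic ring, comes from this assay: 4-methoxyphenyl in place of 3,4-dichlorophenyl gives a 1.9-fold higher number from compound 2 to compound 3 (0.27 log units; within the scatter). Exchanging the two chlorine atoms for a methoxy group, which brings in one hydrogen-bond acceptor at an unchanged heavy-atom count, therefore leaves the reading within the scatter. Compound 1 still adds no number to this comparison, as its reading is a limit: the limit of < 100000 nM in this assay, at which 1 of the 3 values shown sits.

Only these two substituted phenyl groups have numbers at this position, so one step cannot show how far the reading can move there. Open questions are whether a phenyl ring carrying a nitrile, or a longer chain to the nitrogen, would produce a step beyond the scatter.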